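The source may report more compounds than this note shows. Statements on the series, on what has been measured and on what is new or still open speak of the compounds shown alone.

Compound 1, `N=C(N)c1cccc(C(=O)NCC(=O)Nc2ccc(-c3ccccc3S(N)(=O)=O)cc2)c1`, is tested in an assay on isolated protein for inhibition of serine protease 1 (Homo sapiens); on this read-out lower numbers stand for stronger inhibition and higher numbers for weaker inhibition. In this assay compound 1 reaches only a limit, > 10000 nM. Compound 2, `N=C(N)c1cccc(C(=O)N[C@H](C(=O)Nc2ccc(-c3ccccc3S(N)(=O)=O)cc2)C2CCCCC2)c1`, carries a cyclohexyl in place of hydrogen on a saturated chain carbon bound to an amide-type nitrogen and a carbonyl carbon. In this assay compound 2 likewise stops at a limit, > 7930 nM. The step from compound 1 to compound 2 is therefore a step that the two limits leave unreadable from compound 1 to compound 2, as both values sit at limits, namely the limit of > 10000 nM in this assay, at which 1 of the 2 values shown sits, and (the limit of > 7930 nM in this assay, at which 1 of the 2 values shown sits). Among the compounds with values here, compound 2 thus stands on a limit only, and the one further value shown is a limit as well.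

Compound 3 is `N=C(N)c1cccc(C(=O)N[C@@H](CCC(=O)OCc2ccccc2)C(=O)Nc2ccc(-c3ccccc3S(N)(=O)=O)cc2)c1`. It differs from compound 2 by 2-(benzyloxycarbonyl)ethyl in place of cyclohexyl on a saturated chain carbon bound to an amide-type nitrogen and a carbonyl carbon. Within the data shown here, no measured step bears readably on this change, since the only step available is a step that the two limits leave unreadable from compound 1 to compound 2. For compound 3 in this assay the expected step is therefore a step that the limit leaves unreadable from compound 2 to compound 3, with no direction supported beyond the scatter. Compound 3 is estimated at 15000 nM, within 3000 nM to 60000 nM.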

Compound 3, half-maximal inhibitory concentration: 5640 nM
For compound 3 the middle estimate is 2.7-fold (0.42 log units) above the measured one; low and high end bracket the measured number.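

Within the data shown here, compound 3, at 5640 nM, gives the first number in this assay that is not a limit for a group on the saturated chain carbon bound to an amide-type nitrogen and a carbonyl carbon. With 2-(benzyloxycarbonyl)ethyl at this place, two steps can now be read, an at least 1.4-fold lower number from compound 2 to compound 3 (0.14 log units; that floor lies within the scatter) and an at least 1.7-fold lower number from compound 1 to compound 3 (0.24 log units; that floor lies within the scatter). Neither floor reaches beyond the scatter, and compound 2 remains a limit, not a number: the limit of > 7930 nM in this assay, at which 1 of the 3 values shown sits.

The compounds shown do not tell whether the whole 2-(benzyloxycarbonyl)ethyl group or only a part of it goes with the number for compound 3. A carboxylic acid in place of the benzyl ester, or a plain butyl chain on the same carbon, remains an open case in this assay.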